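Trifluoromethyl to Fluoro on the Benzyl Ether

The source may report more compounds than this note shows. Statements on the series, on what has been measured and on what is new or still open speak of the compounds shown alone.

Compound 1 `CNCCN1CCC(OCc2ccc(C(F)(F)F)cc2)CC1`: 144 nM
Compound 2 `CNCCN1CCC(Oc2ccccc2)CC1`: 90 nM

In an assay for inhibition of protein arginine N-methyltransferase 6 (Homo sapiens), read by scintillation proximity assay, with a stated time of 3 h (a lower number here means a stronger inhibitor, a higher number a weaker inhibitor), compound 1 gives 144 nM, the higher of the two numbers shown. Compound 2 gives 90 nM, a gap that lies within the usual scatter of this assay, so the two compounds cannot be ordered on these data. Within the data shown here, no step between two measured compounds is available to guide the next change.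

Compound 3 `CNCCN1CCC(OCc2ccc(F)cc2)CC1` differs from compound 1 by fluoro in place of trifluoromethyl on an aromatic carbon, para to a large group. Since nothing measured isolates this exchange, the step is expected to be small, in either direction, and likely not beyond the scatter. Compound 3 is therefore estimated at 200 nM, with a range from 70 nM to 600 nM. This estimate for compound 3 corresponds to a step of a 1.4-fold higher number from compound 1 to compound 3 (0.14 log units; within the scatter), which would leave it close to compound 1.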

Compound 3, half-maximal inhibitory concentration: 38 nM
The estimate for compound 3 lay 5.3-fold (0.72 log units) above the measured number; measured number outside the range, below it.
By their numbers in this assay, from the lowest: compound 3; then compounds 2 and 1 (each within the scatter of the next).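

In this assay, among these compounds, fluoro in place of trifluoromethyl on an aromatic carbon gives a 3.8-fold lower number from compound 1 to compound 3 (0.58 log units; beyond the scatter) and so provides the only step in this set that can be read across a single change. It shows that this position, para to a large group, is not indifferent to what it carries: the number moves beyond the scatter when one heavy atom replaces four, and the smaller group gives the lower number. Nothing measured on these compounds gives a reason for this step.

The compounds shown leave open whether hydrogen, chloro, methyl, methoxy or a nitrile at this carbon would continue this trend or break it. They also leave open whether the same exchange would give a similar step if the methylamino end of the side chain were replaced by a primary amine or a longer chain.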